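This account rests on a few compounds, and the source may have more. Where it says the series, first, only, none or still open, it means among the compounds named here.

Three compounds share one core and were tested in a functional assay on CHO-K1 cells for antagonist activity at C-X-C chemokine receptor type 3 (Homo sapiens), read by FLIPR, with a stated time of 10 min; on this read-out lower numbers stand for stronger inhibition and higher numbers for weaker inhibition. Compound 1 `CCOc1ncc(-c2nc(C(F)(F)F)sc2N2CCN(C(=O)Cn3nc(C)nc3C)[C@H](C)C2)cn1` gives 7 nM in this assay. Compound 2 `COc1ncc(-c2nc(C(F)(F)F)sc2N2CCN(C(=O)Cn3nc(C)nc3C)[C@H](C)C2)cn1` gives 25 nM. Compound 3 `Cc1ncc(-c2nc(C(F)(F)F)sc2N2CCN(C(=O)Cn3nc(C)nc3C)[C@H](C)C2)cn1` gives 19 nM, the second highest of the three numbers; compound 2 sits within the scatter of it, while compound 1 is beyond it, as the step of a 2.7-fold higher number from compound 1 to compound 3 (0.43 log units; beyond the scatter) shows. Compound 4 `CCCc1ncc(-c2nc(C(F)(F)F)sc2N2CCN(C(=O)Cn3nc(C)nc3C)[C@H](C)C2)cn1` differs from compound 3 by ethyl in place of hydrogen on a saturated chain carbon bound to an aromatic carbon. Going by the values given here, no measured step lengthens a chain on this aromatic carbon; the nearest guide is the chain on the oxygen, where a 3.6-fold higher number from compound 1 to compound 2 (0.55 log units; beyond the scatter) ran against shortening, and a 1.3-fold lower number from compound 2 to compound 3 (0.12 log units; within the scatter) was small. The expected step is therefore a 2.1-fold lower number from compound 3 to compound 4 (0.32 log units; beyond the scatter), a modest lowering. Compound 4 is estimated at 9 nM, between 3 nM and 30 nM.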

Compound 4, half-maximal inhibitory concentration: 4.4 nM
Compound 4: middle estimate off by 2.0-fold (0.31 log units), on the high side, within the range that was stated.
By their numbers in this assay, from the lowest: compounds 4 and 1 (each within the scatter of the next); then compounds 3 and 2 (each within the scatter of the next).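

Going from the methyl of compound 3 to the propyl of compound 4 brought a 4.3-fold lower number from compound 3 to compound 4 (0.64 log units; beyond the scatter) in this assay, the first measured sign that chain length on this aromatic carbon matters, and not only on the oxygen. Propyl also differs clearly from methoxy, with a 5.7-fold lower number from compound 2 to compound 4 (0.75 log units; beyond the scatter), while a 1.6-fold lower number from compound 1 to compound 4 (0.20 log units; within the scatter) gives no order between propyl and ethoxy. No measurement at hand explains the lowering from methyl to propyl. The compounds shown leave open whether a butyl chain on this carbon would lower the number further, and how an amine there would compare with propyl.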